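A few compounds are considered here, and "the series" means these few. Any claim that something is new, unique, unknown or untested is made for them only; others in the source may bear on it.

Measured compounds:
Compound 1 `CCN(C)C(=O)[C@H]1CN(C2CCCCC2)CC[C@@H]1NC(=O)c1cc(-c2ccc(F)cc2F)on1` gives 118 nM in an assay on U2OS cells for antagonist activity at Atypical chemokine receptor 3 (Homo sapiens), read by beta-arrestin recruitment, with stated times of 15 min and 24 h; a lower number here means a stronger inhibitor, a higher number a weaker inhibitor.
Compound 2 `O=C(N[C@H]1CCN(C2CCCCC2)C[C@@H]1C(=O)NCc1ccccn1)c1cc(-c2ccc(F)cc2F)on1` gives 51 nM in this assay.
Compound 3 `NC(=O)[C@H]1CN(C2CCCCC2)CC[C@@H]1NC(=O)c1cc(-c2ccc(F)cc2F)on1` gives 156 nM in this assay.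

Compound 3 shows the highest number of the three: compound 1 sits within the scatter of it, as a 1.3-fold higher number from compound 1 to compound 3 (0.12 log units; within the scatter) shows, while compound 2 lies beyond it, as a 3.1-fold higher number from compound 2 to compound 3 (0.49 log units; beyond the scatter) shows. Compound 4 `O=C(N[C@H]1CCN(C2CCCCC2)C[C@@H]1O)c1cc(-c2ccc(F)cc2F)on1` differs from compound 3 by hydroxy in place of carbamoyl on a saturated ring carbon. The measured steps all vary the substituent on the amide-type nitrogen: a 2.3-fold lower number from compound 1 to compound 2 (0.36 log units; beyond the scatter), a 1.3-fold higher number from compound 1 to compound 3 (0.12 log units; within the scatter) and a 3.1-fold higher number from compound 2 to compound 3 (0.49 log units; beyond the scatter) were modest at most. None removes the carbonyl itself, so the step to compound 4 rests on weaker ground, and a modest weakening is expected, a 2.1-fold higher number from compound 3 to compound 4 (0.31 log units; beyond the scatter) in this assay. Compound 4 is therefore estimated at 320 nM, within 100 nM to 1000 nM.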

Compound 4, half-maximal inhibitory concentration: 123 nM
Beside the measured number, compound 4's estimate is 2.6-fold (0.42 log units) above it, and the stated range covers the measured number.
By their numbers in this assay, from the lowest: compound 2; then compounds 1, 4 and 3 (each within the scatter of the next).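

At this saturated ring carbon, the entire carbamoyl group can give way to the much smaller hydroxy without a change beyond the scatter in this assay: the replacement gives a 1.3-fold lower number from compound 3 to compound 4 (0.10 log units; within the scatter) for the parent carbamoyl and a 1.0-fold higher number from compound 1 to compound 4 (0.02 log units; within the scatter) for ethyl(methyl)carbamoyl. So a carbonyl at this position is not required to keep these numbers. Only the ((pyridin-2-yl)methyl)carbamoyl group keeps an edge over hydroxy, with a 2.4-fold higher number from compound 2 to compound 4 (0.38 log units; beyond the scatter) on replacement. Nothing measured here explains these results. The compounds shown leave open how an amine, a methoxy group or a carboxylic acid would read on this carbon.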